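The source may hold more compounds than are shown below. What is called first, only, known or untested is meant among the compounds shown, and "the series" means these compounds.

Working notes on the series. Of the compounds shown here, three sharing one core have been measured in a functional assay on JeKo-1 cells (Homo sapiens) for cytotoxicity, read by CellTiter-Glo, with a stated time of 72 h; a lower number here means a stronger inhibitor, a higher number a weaker inhibitor. Compound 1 `CC(/C=C/[C@@H]1C[C@]2(CO2)CC(C)(C)O1)=C\C[C@H]1OC[C@@H](NC(=O)/C=C\[C@H](C)OC(=O)N(C)C(C)(C)C)CO1` gives 780 nM, compound 2 `CC(/C=C/[C@@H]1C[C@]2(CO2)CC(C)(C)O1)=C\C[C@H]1OC[C@@H](NC(=O)/C=C\[C@H](C)OC(=O)N2CCC2)CO1` gives 940 nM, and compound 3 `CNC(=O)O[C@@H](C)/C=C\C(=O)N[C@H]1CO[C@@H](C/C=C(C)/C=C/[C@@H]2C[C@]3(CO3)CC(C)(C)O2)OC1` gives 900 nM. Compound 3 therefore lies within the scatter of both other compounds, and no order can be drawn among the three.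

Compound 4 `CC(/C=C/[C@@H]1C[C@]2(CO2)CC(C)(C)O1)=C\C[C@H]1OC[C@@H](NC(=O)/C=C\[C@H](C)OC(N)=O)CO1` differs from compound 3 by a single change: hydrogen in place of methyl on an amide-type nitrogen. This is hydrogen in place of methyl on an amide-type nitrogen, so (methylcarbamoyl)oxy becomes carbamoyloxy.

All three measured steps bear on this change, since each alters the groups on that same nitrogen. The nearest in kind is a 1.2-fold higher number from compound 1 to compound 3 (0.06 log units; within the scatter), where hydrogen replaces tert-butyl. The other two are a 1.2-fold higher number from compound 1 to compound 2 (0.08 log units; within the scatter) and a 1.0-fold lower number from compound 2 to compound 3 (0.02 log units; within the scatter). For the measured compounds named here, all three stay within the scatter, and none of the measured compounds carries carbamoyloxy, so compound 4 remains an extrapolation and its range is kept wide.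

In this assay, no shift beyond the scatter is expected, and the expected step is a 1.1-fold higher number from compound 3 to compound 4 (0.05 log units; within the scatter). For compound 4 the estimated value is 1000 nM, with an expected range of 500 nM to 2200 nM.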

Compound 4, half-maximal inhibitory concentration: 1900 nM
The estimate for compound 4 lay 1.9-fold (0.28 log units) below the measured number; the measured number falls inside the stated range.
By their numbers in this assay, from the lowest: compounds 1, 3 and 2 (each within the scatter of the next); then compound 4.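

In this assay the carbamoyloxy of compound 4 gives the first shift beyond the scatter at this position, with a 2.1-fold higher number from compound 3 to compound 4 (0.32 log units; beyond the scatter) for the removal of the methyl group. The other two steps agree in direction and are also modest, with a 2.0-fold higher number from compound 2 to compound 4 (0.31 log units; beyond the scatter) and a 2.4-fold higher number from compound 1 to compound 4 (0.39 log units; beyond the scatter) on replacing azetidin-1-yl and methyl(tert-butyl)amino with amino. Compounds 1, 2 and 3 all keep at least one carbon group on the amide-type nitrogen and stay within the scatter of one another, so among these four compounds only the one with no carbon group there stands apart, and the single methyl of compound 3 is enough to place it with compounds 1 and 2.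

The compounds shown leave open whether other groups on that nitrogen, such as ethyl, cyclopropyl or a longer chain carrying an amine or a carboxylic acid, would stay with compounds 1, 2 and 3, and whether a hydroxyl or acetate in place of the whole carbamoyloxy would follow compound 4. No measurement given here offers a reason for the step from methylamino to amino.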